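The compounds below may be only part of what the source reports. "The series", "measured", "known", "first", "only" and "open" are said of these compounds alone.

Measured compounds:
- Compound 1, `Fc1ccc2nc(NC(=S)Nc3ccc(Cl)cc3)sc2c1`, in a functional assay on THP-1 cells (Homo sapiens) for cytotoxicity, read by MTT assay, with a stated time of 48 h (a lower number here means a stronger inhibitor, a higher number a weaker inhibitor), gives 31200 nM.
- Compound 2, `Fc1ccc(NC(=S)Nc2nc3ccc(F)cc3s2)cc1`, in this assay gives 34600 nM.

Compound 2 carries the highest of the two numbers, and its nearest neighbour is compound 1; the step of a 1.1-fold higher number from compound 1 to compound 2 (0.04 log units; within the scatter) shows that the two lie within the scatter of each other, so no order between them can be read from these numbers.

The next compound, compound 3, `Cc1ccc2nc(NC(=S)Nc3ccc(F)cc3)sc2c1`, arises from compound 2 by one change: methyl in place of fluoro on an aromatic carbon. Among the compounds with values here, this change sits on the shared core rather than on the substituted phenyl ring, where the only measured step took place. That step, a 1.1-fold higher number from compound 1 to compound 2 (0.04 log units; within the scatter), exchanged one small substituent for another and produced nothing beyond the scatter. Within the data shown here, no measured step tests a change on the core itself, so the only guide is the observation that a small substituent exchange elsewhere left this assay untouched. On that basis compound 3 is expected to stay near compound 2, with the step of a 1.0-fold higher number from compound 2 to compound 3 (0.00 log units; within the scatter) estimated to fall within the scatter. The value expected for compound 3 in this assay is 35000 nM, with a range from 15000 nM to 80000 nM.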

Compound 3, half-maximal inhibitory concentration: 36900 nM
Compound 3: middle estimate off by 1.1-fold (0.02 log units), on the low side; the range from low to high includes it.
By their numbers in this assay, from the lowest: compounds 1, 2 and 3 (each within the scatter of the next).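

In this assay, within the data shown here, the earlier step had varied only the substituent on the separate phenyl ring, whereas this one gives the first reading on an aromatic carbon of the ring fused into the two-ring system, and it comes out as a 1.1-fold higher number from compound 2 to compound 3 (0.03 log units; within the scatter). At this position, then, methyl and fluoro cannot be told apart in this assay, even though the entering group is a carbon and the leaving group a fluorine, and a one-atom exchange on the fused system leaves the reading as undisturbed as the exchange on the phenyl ring did. Nothing available bears on why the reading holds across this exchange.

The compounds shown carry only single-atom substituents at this aromatic carbon, so it remains open whether a larger or differently built group there, such as an amine, a carboxylic acid or a longer chain like butyl, would shift the number beyond the scatter. Among these compounds, it is also open whether any such group would matter more on the fused ring than on the phenyl ring, since every step so far stays within the scatter.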